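Two measured analogues and one untested piperidine variant

A few compounds are considered here, and "the series" means these few. Any claim that something is new, unique, unknown or untested is made for them only; others in the source may bear on it.

Measured so far:
compound 1, `Cc1csc2cc([C@H](C)Nc3ncnc(N)c3C#N)c(-c3cccc(CN4CCC(N(C)CC(C)C)CC4)c3)c(=O)n12`, 6.8
compound 2, `Cc1csc2cc([C@H](C)Nc3ncnc(N)c3C#N)c(-c3cccc(CN(C)CCCN(C)Cc4ccc(Cl)cc4)c3)c(=O)n12`, 7.5

Compound 1 and compound 2 share a core and differ in the group carried on the benzylic position of the phenyl ring. Within the data shown here, in a physicochemical assay for acid dissociation, compound 1 gives 6.8, the lower of the two numbers known; compound 2 gives 7.5, which lies beyond the scatter above compound 1. Among the measured compounds shown here, no pair differing in a single place has been measured, so the two values stand on their own and no step can be read from them.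

Compound 3, `Cc1csc2cc([C@H](C)Nc3ncnc(N)c3C#N)c(-c3cccc(CN4CCC(CN(C)Cc5ccccn5)CC4)c3)c(=O)n12`, has not yet been measured. It differs from compound 1 in one place: (methyl((pyridin-2-yl)methyl)amino)methyl in place of isobutyl(methyl)amino on a saturated ring carbon. Nothing in the two measured values tells how such an exchange on the saturated ring carbon moves the read-out, so the expected step is taken as small, a number 0.20 log units higher from compound 1 to compound 3 (within the scatter), not beyond the scatter, with the direction left open. Compound 3 is therefore estimated at 7, with a range of 6.3 to 7.8.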

Compound 3, acid dissociation constant: 7
The estimate for compound 3 equals the measured number at the digits printed; the range from low to high includes it.
By their numbers in this assay, from the lowest: compounds 1 and 3 (each within the scatter of the next); then compound 2.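

In this assay, among these compounds, the exchange of isobutyl(methyl)amino for (methyl((pyridin-2-yl)methyl)amino)methyl gives the first step that can be read, a number 0.20 log units higher from compound 1 to compound 3 (within the scatter), and it lies on a saturated ring carbon, three ring bonds from the ring nitrogen. At this place, a group of 10 heavy atoms with one six-membered aromatic ring and 2 hydrogen-bond acceptors thus stands in for one of 6 heavy atoms with no ring and 1 hydrogen-bond acceptor, and the read-out stays within the scatter. No measurement is available that would account for this result.

The single step changes the ring and the length of the group together, so the compounds shown do not separate the pyridin-2-yl ring from the rest of the exchange, and a phenyl ring in its place would bear on that question. They also leave open whether a carboxylic acid or a primary amine on a longer chain at this saturated ring carbon would shift the read-out beyond the scatter.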